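Chloro for Fluoro on a Selenocyanate Carbamate

This account rests on a few compounds, and the source may have more. Where it says the series, first, only, none or still open, it means among the compounds named here.

The account begins with compound 1, `N#C[Se]c1ccc(NC(=O)Oc2ccc(F)cc2)cc1`, a selenocyanate carrying an aryl carbamate. In a functional assay on PC-3 cells (Homo sapiens) for cytotoxicity, read by MTT assay, with a stated time of 72 h (a lower number here means a stronger inhibitor of growth, a higher number a weaker inhibitor of growth), compound 1 gives 11800 nM. For the measured compounds named here, the only other measured compound is compound 2, `CCCCOC(=O)Nc1ccc([Se][Se]c2ccc(NC(=O)OCCCC)cc2)cc1`, a diselenide with butyl carbamates, which in this assay gives 28600 nM. Of the two numbers available, that of compound 1 is the lower, and the gap to compound 2 lies beyond the usual scatter, so compound 1 stands as the stronger growth inhibitor of the pair. The two structures differ in more than one place, so the gap cannot be assigned to any single feature.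

Compound 3, `N#C[Se]c1ccc(NC(=O)Oc2ccc(Cl)cc2)cc1`, differs from compound 1 in one place: chloro in place of fluoro on an aromatic carbon. Going by the values given here, no measured pair in this set shows what such an exchange does. Since nothing in the data speaks for a large effect of this change, the step is expected to be small, with a slight lean toward a lower number, and not clearly beyond the scatter. Compound 3 is therefore estimated to give 9500 nM in this assay, within a range from 4000 nM to 24000 nM, which corresponds to an expected step of a 1.2-fold lower number from compound 1 to compound 3 (0.09 log units; within the scatter).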

Compound 3, concentration for 50% growth inhibition: 6400 nM
Estimate against measurement, compound 3: 1.5-fold (0.17 log units) above, and the stated range covers the measured number.
By their numbers in this assay, from the lowest: compounds 3 and 1 (each within the scatter of the next); then compound 2.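

Chloro in place of fluoro on an aromatic carbon, para to a large group, is the first exchange in this set that can be read at a single place: in this assay it gives a 1.8-fold lower number from compound 1 to compound 3 (0.27 log units; within the scatter). This position therefore accepts either halogen, and the assay does not tell compound 1 and compound 3 apart, so the exchange of one halogen for the other gives no firm gain or loss in growth inhibition. No measurement at hand bears on why the step has this size.

The compounds shown leave open what other groups on this aromatic carbon would do, whether bromo, methoxy, an amine or a carboxylic acid, and whether a change of that kind would move the number beyond the scatter. Also open, from the compounds shown here alone, is what the selenocyanate contributes on its own: compound 2 differs from compound 1 in more than one place, and its number cannot settle that question.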